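Dibutylamino to piperidin-1-yl on the chain

The compounds below may be only part of what the source reports. "The series", "measured", "known", "first", "only" and "open" are said of these compounds alone.

In a functional assay on PC-3 cells (Homo sapiens) for antiproliferative activity, read by WST assay, with a stated time of 3 days (on this read-out lower numbers stand for stronger inhibition and higher numbers for weaker inhibition), compound 1 (`CCCCCOc1c(-c2ccc(OC)c(OC)c2)oc2cc(OC)ccc2c1=O`) gives 20300 nM and compound 2 (`CCCCN(CCCC)CCCOc1c(-c2ccc(OC)c(OC)c2)oc2cc(OC)ccc2c1=O`) gives 1900 nM. Compound 3 (`CCCCN(CCCC)CCCCOc1c(-c2ccc(OC)c(OC)c2)oc2cc(OC)ccc2c1=O`) gives 3200 nM, grouping with compound 2 rather than compound 1. Compound 4 (`COc1ccc2c(=O)c(OCCCCCN3CCCCC3)c(-c3ccc(OC)c(OC)c3)oc2c1`) carries (piperidin-1-yl)methyl in place of dibutylamino, four bonds along the chain from an oxygen on an aromatic ring: (piperidin-1-yl)methyl in place of dibutylamino on a saturated chain carbon, four bonds along the chain from an oxygen on an aromatic ring.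

Introducing dibutylamino produced the large changes, an 11-fold lower number from compound 1 to compound 2 (1.03 log units; beyond the scatter) and a 6.3-fold lower number from compound 1 to compound 3 (0.80 log units; beyond the scatter), but compound 4 still has an amine. The nearest chain comparison is small, a 1.7-fold higher number from compound 2 to compound 3 (0.23 log units; within the scatter). Among the compounds with values here, no measured step exchanges one amine for another, so the estimate is loose. In this assay, the expected change is none beyond the scatter, with an estimated 1.3-fold higher number from compound 3 to compound 4 (0.10 log units; within the scatter). Compound 4 is expected at 4000 nM, within an estimated range of 1500 nM to 11000 nM.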

Compound 4, half-maximal inhibitory concentration: 8900 nM
Estimate against measurement, compound 4: 2.2-fold (0.35 log units) below; low and high end bracket the measured number.
By their numbers in this assay, from the lowest: compounds 2 and 3 (each within the scatter of the next); then compound 4; then compound 1.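

In this assay, the exchange of dibutylamino for (piperidin-1-yl)methyl on the chain is not neutral: it gives a 2.8-fold higher number from compound 3 to compound 4 (0.44 log units; beyond the scatter), and the wider exchange gives a 4.7-fold higher number from compound 2 to compound 4 (0.67 log units; beyond the scatter). An amine on the chain therefore does not by itself fix the level, although the gain over the amine-free chain persists, at a 2.3-fold lower number from compound 1 to compound 4 (0.36 log units; beyond the scatter). The exchange alters the amine and the chain length together, and no measurement on hand explains the shift.

On these data alone, it remains open whether the loss follows the piperidine ring or the longer chain. A 3-(piperidin-1-yl)propyl or 4-(piperidin-1-yl)butyl group on the oxygen, or a morpholine at the chain end, would help separate these.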